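The source may report more compounds than this note shows. Statements on the series, on what has been measured and on what is new or still open speak of the compounds shown alone.

Three compounds have been run through a functional assay on HCT-116 cells (Homo sapiens) for inhibition, read by sulforhodamine B assay, with a stated time of 72 h (a lower number here means a stronger inhibitor, a higher number a weaker inhibitor), and among them compound 1, whose structure is `COc1ccc2cc(C(C)c3nnc4n3N=C(c3ccc(OC(F)(F)F)cc3)CS4)ccc2c1`, stands second highest of three with 11700 nM. Compound 3, with the structure `CC(c1ccc(-c2ccccc2)c(F)c1)c1nnc2n1N=C(c1ccc(Cl)cc1Cl)CS2`, gives 6900 nM in this assay; the gap between compound 1 and compound 3 lies within the scatter, so nothing separates them. Compound 2, built as `CC(C)Cc1ccc(C(C)c2n[nH]c(=S)n2N)cc1`, gives 27400 nM in this assay, a number beyond the scatter from that of compound 1.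

The compound not yet measured is compound 4, with the structure `COc1ccc2cc(C(C)c3nnc4n3N=C(c3ccc(Cl)cc3Cl)CS4)ccc2c1`. It keeps the shared core of compound 1 and differs in one place: 2,4-dichlorophenyl in place of 4-(trifluoromethoxy)phenyl on a carbon with a double bond to nitrogen. Among the compounds with values here, no pair of measured compounds shows this change on its own, so its size is not known. Compound 3 carries the same 2,4-dichlorophenyl group and reaches 6900 nM, which gives some ground for thinking the group is tolerated on this core. Compound 4 is therefore expected to land close to compound 1, with a step of a 1.4-fold lower number from compound 1 to compound 4 (0.14 log units; within the scatter) that is expected to stay within the scatter, though a modest gain is also possible. Compound 4 is estimated at 8500 nM in this assay, with a plausible range from 3000 nM to 25000 nM.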

Compound 4, half-maximal inhibitory concentration: 14000 nM
Beside the measured number, compound 4's estimate is 1.6-fold (0.22 log units) below it; the range from low to high includes it.
By their numbers in this assay, from the lowest: compounds 3, 1, 4 and 2 (each within the scatter of the next, the first and the last beyond it).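

In this assay, within the data shown here, the exchange of 4-(trifluoromethoxy)phenyl for 2,4-dichlorophenyl on a carbon with a double bond to nitrogen gives a 1.2-fold higher number from compound 1 to compound 4 (0.08 log units; within the scatter) and so provides the first direct reading of this change on the shared core, showing that the two groups are not separated at this position. The group that leaves has more heavy atoms and holds an oxygen with a hydrogen-bond acceptor, while the group that enters has two chlorine atoms and no acceptor, yet this difference in make-up leaves no measurable separation in this one pair. Nothing available here explains why the two groups read alike.

The compounds shown leave open whether a quite different group at this position, such as an amine, a carboxylic acid or a plain unsubstituted phenyl, would separate from these two. Among these compounds, they also leave open whether the same exchange would read alike with another group in place of the methoxy-bearing part of compound 1, as this single pair is the only direct reading of the change.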